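Rhodanine series: methyl replacing acetoxyphenyl on the ring nitrogen

The source may hold more compounds than are shown below. What is called first, only, known or untested is meant among the compounds shown, and "the series" means these compounds.

Compound 2 `CC(=O)Oc1ccc(N2C(=O)/C(=C/N3N=C(c4ccc5ccccc5c4)CC3c3ccccc3O)SC2=S)cc1` stands lowest of the two numbers in a functional assay on HL-60 cells (Homo sapiens) for antiproliferative activity, read by MTT assay, with a stated time of 72 h (on this read-out higher numbers stand for weaker inhibition and lower numbers for stronger inhibition), giving 500 nM. Compound 1 `CN1C(=O)/C(=C/N2N=C(c3ccccc3)CC2c2ccccc2O)SC1=S` differs from it in two places and gives 2880 nM in this assay, a gap beyond the scatter. Compound 3 `CN1C(=O)/C(=C/N2N=C(c3ccc4ccccc4c3)CC2c2ccccc2O)SC1=S` is a single change away from compound 2: methyl in place of 4-acetoxyphenyl on an amide-type nitrogen in a ring. Going by the values given here, no single step of this kind is measured here, and compound 1 carries the same methyl with a weaker number, so a moderate rise is expected, estimated as a 2.4-fold higher number from compound 2 to compound 3 (0.38 log units; beyond the scatter). For compound 3 the expected value in this assay is 1200 nM, within 400 nM to 3500 nM.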

Compound 3, half-maximal inhibitory concentration: > 10000 nM
Compound 3 gave a limit, no number (the forecaster's own chance of this, stated with the estimate: 5%); middle value at least 8.3-fold (0.92 log units) away from the limit.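

In this assay, methyl in place of 4-acetoxyphenyl on the amide-type nitrogen in the ring gives an at least 20-fold higher number from compound 2 to compound 3 (1.30 log units; beyond the scatter), so this position is not indifferent to the group it carries. With methyl held there, naphthalen-2-yl in place of phenyl gives an at least 3.4-fold higher number from compound 1 to compound 3 (0.54 log units; beyond the scatter), so naphthalen-2-yl brings no gain in that setting. Compound 3 is a limit, not a number: the limit of > 10000 nM in this assay, at which 1 of the 3 values shown sits.

Open, on these data alone, is whether the acetoxy group or the phenyl ring matters at this nitrogen; a plain phenyl or a 4-hydroxyphenyl there would separate the two. Also open, as far as these compounds go, is how phenyl in place of naphthalen-2-yl behaves with 4-acetoxyphenyl on the nitrogen.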